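Swapping a Prenyl Chain for a Chlorobenzyl Group

This account rests on a few compounds, and the source may have more. Where it says the series, first, only, none or still open, it means among the compounds named here.

Compound 1 `CC(C)=CCn1c(CN2CCN(C(=O)C3CC3)CC2)nc2ccccc21` is one of three compounds that share a core and differ at two outer positions. In an assay on isolated protein for inhibition of retinal dehydrogenase 2 (Homo sapiens), read by spectrophotometry (a higher number here means a weaker inhibitor, a lower number a stronger inhibitor), compound 1 gives 1620 nM. Compound 2 `CCC(=O)N1CCN(Cc2nc3ccccc3n2Cc2cccc(C)c2)CC1` gives 2090 nM, and compound 3 `Cc1cccc(Cn2c(CN3CCN(C(=O)C(C)C)CC3)nc3ccccc32)c1` gives 2780 nM. Compound 1 has the lowest of the three numbers, but its gap to compound 2 and to compound 3 sits within the usual scatter, so the three cannot be ranked. Within the data shown here, the only change measured in one place, a 1.3-fold higher number from compound 2 to compound 3 (0.12 log units; within the scatter), concerns the amide end of the molecule and shows no effect beyond the scatter.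

Compound 4 `O=C(C1CC1)N1CCN(Cc2nc3ccccc3n2Cc2cccc(Cl)c2)CC1` differs from compound 1 at the other end: 3-chlorophenyl in place of 2-methylprop-1-en-1-yl on a saturated chain carbon bound to an aromatic nitrogen. Among the measured compounds shown here, no measured pair isolates this change; compound 1 and compound 2 differ both here and at the amide, and their two values lie within the scatter of each other. With nothing pointing to a shift, the number for compound 4 is expected to stay close to that of compound 1, with a 1.0-fold lower number from compound 1 to compound 4 (0.01 log units; within the scatter) as the estimated step, giving an estimate of 1600 nM with a range from 500 nM to 5000 nM.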

Compound 4, half-maximal inhibitory concentration: 890 nM
The estimate for compound 4 lay 1.8-fold (0.25 log units) above the measured number; the range from low to high includes it.
By their numbers in this assay, from the lowest: compounds 4, 1, 2 and 3 (each within the scatter of the next, the first and the last beyond it).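

Among these compounds, this is the first measurement that isolates a change at this position, on a saturated chain carbon bound to an aromatic nitrogen. In this assay, exchanging the open 3-methylbut-2-en-1-yl chain for 3-chlorobenzyl gives a 1.8-fold lower number from compound 1 to compound 4 (0.26 log units; within the scatter), so a group with a six-membered aromatic ring and a chlorine can stand where the prenyl chain stood without a change that rises above the scatter, at least with the shared core and amide of compound 1. Nothing measured here offers an explanation for this result.

On these data alone, the chlorine and the ring remain untested as separate contributors, since this step exchanges the whole group at once. Still open, as far as these compounds go, is how this position would respond to a plain benzyl group, a longer chain, or a benzyl group carrying an amine or a carboxylic acid in place of the chlorine.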